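The source may report more compounds than this note shows. Statements on the series, on what has been measured and on what is new or still open speak of the compounds shown alone.

Compound 1 `O=C(NO)c1ccc(NCCOc2ccc3cc2COC/C=C/COCc2cccc(c2)-c2ccnc(n2)N3)cc1` is one of three macrocycles examined in an assay on Sf9 cells for inhibition of protein deacetylase HDAC6 (Homo sapiens), read by fluorescence, with a stated time of 2 h (on this read-out higher numbers stand for weaker inhibition and lower numbers for stronger inhibition), where compound 1 gives 395 nM. Among the numbers shown, compound 1 stands highest; its nearest companion, compound 3 `O=C(NO)c1ccc(OCCOc2ccc3cc2COC/C=C/COCc2cccc(c2)-c2ccnc(n2)N3)cc1`, gives 66 nM in this assay, and the step of a 6.0-fold lower number from compound 1 to compound 3 (0.78 log units; beyond the scatter) goes beyond the usual scatter. Compound 2 `O=C(O)c1ccc(OCCOc2ccc3cc2COC/C=C/COCc2cccc(c2)-c2ccnc(n2)N3)cc1` is reported only as a limit of the assay, > 100000 nM, and so the limit of > 100000 nM in this assay, at which 1 of the 3 values shown sits, marks it rather than a measured number. The step of an at least 250-fold higher number from compound 1 to compound 2 (2.40 log units; beyond the scatter), and the step of an at least 1500-fold lower number from compound 2 to compound 3 (3.18 log units; beyond the scatter), both show how much the hydroxycarbamoyl group matters, but neither of them speaks to where that group sits on its ring.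

Compound 4 `O=C(NO)c1cccc(NCCOc2ccc3cc2COC/C=C/COCc2cccc(c2)-c2ccnc(n2)N3)c1` keeps the same atoms as compound 1, joined differently: 3-(hydroxycarbamoyl)phenyl in place of 4-(hydroxycarbamoyl)phenyl on an amine nitrogen. Among the compounds with values here, no measured pair in this set moves the hydroxycarbamoyl group from one ring position to another, so the expectation rests on the observation that every measured compound carries its group at the 4-position and that compound 3 and compound 1 both bind well there. The author expects a somewhat higher number for compound 4, a step of a 3.8-fold higher number from compound 1 to compound 4 (0.58 log units; beyond the scatter), and estimates compound 4 at 1500 nM in this assay, with a range from 300 nM to 8000 nM.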

Compound 4, half-maximal inhibitory concentration: 2900 nM
Compound 4: the middle estimate sits 1.9-fold (0.29 log units) below what was measured, within the range that was stated.
By their numbers in this assay, from the lowest: compound 3; then compound 1; then compound 4. At a limit, above all of these: compound 2.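

Moving the hydroxycarbamoyl group on the ring attached to the amine nitrogen, with every atom kept, gives a 7.3-fold higher number from compound 1 to compound 4 (0.87 log units; beyond the scatter) in this assay, and this is the first direct measure of how much its ring position counts, since 3-(hydroxycarbamoyl)phenyl is clearly less favourable here than 4-(hydroxycarbamoyl)phenyl. A wider gap appears against the best compound shown, a 44-fold higher number from compound 3 to compound 4 (1.64 log units; beyond the scatter), but that change also replaces the oxygen-linked group with an amino-linked one, so the contribution of ring position and that of the linking atom cannot be separated within it. The step of an at least 34-fold lower number from compound 2 to compound 4 (1.53 log units; beyond the scatter) starts from compound 2, whose entry is a limit of the assay: the limit of > 100000 nM in this assay, at which 1 of the 4 values shown sits.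

Nothing shown here bears on why the ring position matters to this extent. From the compounds shown here alone, it also remains open whether 3-(hydroxycarbamoyl)phenoxy would lose as much against compound 3 as the amino pair does against compound 1, and how a longer chain, or a methyl group on the amine nitrogen, would act on the 4-(hydroxycarbamoyl)phenyl arrangement.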